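This account rests on a few compounds, and the source may have more. Where it says the series, first, only, none or still open, it means among the compounds named here.

Among the compounds with values here, in a functional assay on HL-60 cells (Homo sapiens) for cytotoxicity, read by CCK-8 assay, with a stated time of 24 h (on this read-out lower numbers stand for stronger inhibition and higher numbers for weaker inhibition), compound 1 `C=CC(=O)N1C(=O)CC(c2ccc(OC)cc2)Sc2ccccc21` gives 92100 nM, the second highest of the three numbers measured so far. Compound 2 `C=CC(=O)N1C(=O)CCSc2ccccc21` carries hydrogen in place of 4-methoxyphenyl on a saturated ring carbon and gives 44800 nM. Compound 3 `C=CC(=O)N1C(=O)CC(c2cccs2)Sc2ccccc21` carries thiophen-2-yl on that carbon and gives 695000 nM.

The open question is compound 4 `C=CC(=O)N1C(=O)CC(c2ccc([N+](=O)[O-])cc2)Sc2ccccc21`, which has nitro in place of methoxy on an aromatic carbon, para to a large group (nitro in place of methoxy on an aromatic carbon). Within the data shown here, no measured step changes a group at that place, so the evidence is only indirect. The three measured steps all concern the saturated ring carbon. They are a 2.1-fold lower number from compound 1 to compound 2 (0.31 log units; beyond the scatter), a 7.5-fold higher number from compound 1 to compound 3 (0.88 log units; beyond the scatter) and a 16-fold higher number from compound 2 to compound 3 (1.19 log units; beyond the scatter). These steps show that the number can move in either direction when the group on that carbon changes, from a modest to a large extent. They give no direction for a change on the aromatic carbon. No clear shift beyond the scatter is therefore expected, although a modest step either way would not be surprising. The expected step, an estimate only, is a 1.2-fold higher number from compound 1 to compound 4 (0.08 log units; within the scatter). Compound 4 is expected at an estimated 110000 nM, within an expected range of 35000 nM to 350000 nM.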

Compound 4, half-maximal inhibitory concentration: 107000 nM
The estimate for compound 4 lay 1.0-fold (0.01 log units) above the measured number; low and high end bracket the measured number.
By their numbers in this assay, from the lowest: compound 2; then compounds 1 and 4 (each within the scatter of the next); then compound 3.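

In this assay, within the data shown here, exchanging methoxy for nitro on the aromatic carbon, para to a large group, gives a 1.2-fold higher number from compound 1 to compound 4 (0.07 log units; within the scatter) and so offers the first direct look at this position: this exchange produces no shift beyond the scatter. The earlier steps, all on the saturated ring carbon, had each moved the number beyond the scatter, so among these compounds, replacing the whole group on that carbon counted for more than this change on the aromatic ring. Nothing available accounts for this lack of a shift between the two groups.

Methoxy and nitro are the only two groups seen at this aromatic place, so it remains open whether an amine or a carboxylic acid there would also leave the number unchanged or would shift it beyond the scatter. From the compounds shown here alone, it also remains open how a longer chain in place of the 4-methoxyphenyl on the saturated ring carbon would compare, given how far apart compound 2 and compound 3 lie.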